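The source may report more compounds than this note shows. Statements on the series, on what has been measured and on what is new or still open speak of the compounds shown alone.

The measured compounds:

Compound 1, `C=C1C[C@]23C[C@@]1(O)CC[C@H]2c1cc(Br)c(O)c(C)c1[C@@H]3Cn1cc(-c2ccccn2)nn1`. In a functional assay on MCF7 cells (Homo sapiens) for cytotoxicity, read by MTT assay, with a stated time of 4 days (on this read-out higher numbers stand for weaker inhibition and lower numbers for stronger inhibition), compound 1 gives > 20000 nM, which is a limit of the assay rather than a number.

Compound 2, `C=C1C[C@]23C[C@@]1(O)CC[C@H]2c1ccc(O)c(C)c1[C@@H]3Cn1cc(-c2ccccn2)nn1`. In this assay compound 2 gives > 20000 nM, again a limit.

Compound 3, `Cc1ccc(S(=O)(=O)Oc2ccc3c(c2C)[C@H](Cn2cc(-c4ccc(Br)cc4)nn2)[C@@]24CC(=O)[C@@](C)(CC[C@@H]32)C4)cc1`. In this assay compound 3 gives > 20000 nM, also a limit.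

Compound 1 therefore stands only at a limit: no number is known for it, and the same holds for every other compound measured here, since (the limit of > 20000 nM in this assay, at which 3 of the 3 values shown sit). For the measured compounds named here, the one change between measured compounds that touches a single place, hydrogen in place of bromo on an aromatic carbon, runs a step that the two limits leave unreadable from compound 1 to compound 2; both of its ends are limits, so its size cannot be read. Compound 4 is `C=C1C[C@]23C[C@@]1(O)CC[C@H]2c1cc(Br)c(O)c(C)c1[C@@H]3Cn1cc(-c2ccc(C(F)(F)F)cc2)nn1`. It differs from compound 1 by 4-(trifluoromethyl)phenyl in place of pyridin-2-yl on an aromatic carbon. Going by the values given here, no measured pair differs at that place, so nothing measured bears on this change, and no direction or size of step can be expected beyond the scatter from the data alone. Compound 4 is expected to behave like compound 1. For compound 4 the value in this assay is estimated at 20000 nM, within 8000 nM to 60000 nM, which means an expected step of a number no higher from compound 1 to compound 4 (the limit leaves the size open).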

Compound 4, half-maximal inhibitory concentration: 8100 nM
Estimate against measurement, compound 4: 2.5-fold (0.39 log units) above; measured number inside the range.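

Replacing pyridin-2-yl with 4-(trifluoromethyl)phenyl on the aromatic carbon of the five-membered ring with 3 nitrogen gives, in this assay, an at least 2.4-fold lower number from compound 1 to compound 4 (0.39 log units; beyond the scatter). For the compounds shown here, this is the first step here that can be read, as the earlier step between two limits cannot, and it shows that the group at this position can shift the read-out on the core of compound 1. The true size of the step stays open, because compound 1 has no number of its own and compound 4 is the only compound shown that does: the limit of > 20000 nM in this assay, at which 3 of the 4 values shown sit.

From the compounds shown here alone, the swap removes a ring nitrogen and adds a trifluoromethyl group in a single move, so it remains open which of the two goes with the lower number, and a plain phenyl group at this position would separate them. Also open, going by these compounds, are whether the same swap would lower the number on compound 2, which has hydrogen in place of bromo, and how a phenyl ring carrying an amine or a carboxylic acid in place of trifluoromethyl would read.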